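N-Methylation of the sulfonamide on a pyridone series

The compounds below may be only part of what the source reports. "The series", "measured", "known", "first", "only" and "open" are said of these compounds alone.

Compound 1 `CCCCc1ccc(CNCc2ccccc2)c(=O)n1Cc1ccc(-c2ccccc2-c2nn[nH]n2)cc1`: 1 nM
Compound 2 `CCCCc1ccc(CNC(=O)Nc2ccccc2)c(=O)n1Cc1ccc(-c2ccccc2-c2nn[nH]n2)cc1`: 30 nM
Compound 3 `CCCCc1ccc(CNS(C)(=O)=O)c(=O)n1Cc1ccc(-c2ccccc2-c2nn[nH]n2)cc1`: 2 nM

In a functional assay (aorta) for antagonist activity, with Oryctolagus cuniculus as the target (a higher number here means a weaker inhibitor, a lower number a stronger inhibitor), compound 3 gives 2 nM, the second highest of the three numbers; the difference a 2.0-fold higher number from compound 1 to compound 3 (0.30 log units; within the scatter) lies within the scatter, while a 15-fold lower number from compound 2 to compound 3 (1.18 log units; beyond the scatter) is a large drop. Compound 4 `CCCCc1ccc(CN(C)S(C)(=O)=O)c(=O)n1Cc1ccc(-c2ccccc2-c2nn[nH]n2)cc1` differs from compound 3 by methyl in place of hydrogen on a sulfonamide nitrogen. For the measured compounds named here, none of the measured steps adds a methyl to that nitrogen; all of them swap the whole group on the amine nitrogen, and they range from the small 2.0-fold higher number from compound 1 to compound 3 (0.30 log units; within the scatter) to the large 30-fold higher number from compound 1 to compound 2 (1.48 log units; beyond the scatter). Going by the values given here, with no direct precedent, the step of a 2.0-fold higher number from compound 3 to compound 4 (0.30 log units; within the scatter) is expected to stay within or near the scatter. Compound 4 is therefore estimated at 4 nM, within 1 nM to 15 nM.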

Compound 4, half-maximal inhibitory concentration: 0.2 nM
Estimate against measurement, compound 4: 20-fold (1.30 log units) above; the measured number lies below the stated range.
By their numbers in this assay, from the lowest: compound 4; then compounds 1 and 3 (each within the scatter of the next); then compound 2.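

On the sulfonamide nitrogen, in this assay, one added methyl changes the outcome beyond the scatter, with a 10-fold lower number from compound 3 to compound 4 (1.00 log units; beyond the scatter) as the step. The methylated group also outdoes the benzylamino group, giving a 5.0-fold lower number from compound 1 to compound 4 (0.70 log units; beyond the scatter) as the step, and the gap to the (phenylcarbamoyl)amino group widens to a 150-fold lower number from compound 2 to compound 4 (2.18 log units; beyond the scatter) as the step. No evidence bears on the reason for this gain.
Going by these compounds, whether ethyl or a longer chain on that nitrogen would keep the gain remains open. So does the effect of replacing the methyl on the sulfonyl sulfur with phenyl.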